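A Trifluoromethoxy Group on the Sulfonyl Sulfur

The compounds below may be only part of what the source reports. "The series", "measured", "known", "first", "only" and "open" are said of these compounds alone.

In a functional assay on CWR22R cells (Homo sapiens) for antiproliferative activity, read by propidium iodide staining, with a stated time of 96 h (on this read-out lower numbers stand for stronger inhibition and higher numbers for weaker inhibition), compound 1 `CC(O)(CS(=O)(=O)c1ccc(C(F)(F)F)cc1)C(=O)Nc1ccc(S(F)(F)(F)(F)F)cc1` gives 28900 nM. Among the compounds with values here, compound 2 `CC(O)(CS(=O)(=O)c1cccc(C(F)(F)F)c1)C(=O)Nc1ccc(S(F)(F)(F)(F)F)cc1` gives 23800 nM, and these two values lie within the scatter of each other, so compound 2 stands level with compound 1 on the numbers so far.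

The next compound is compound 3 `CC(O)(CS(=O)(=O)c1ccc(OC(F)(F)F)cc1)C(=O)Nc1ccc(S(F)(F)(F)(F)F)cc1`, and the change from compound 2 is 4-(trifluoromethoxy)phenyl in place of 3-(trifluoromethyl)phenyl on a sulfonyl sulfur. In words, 4-(trifluoromethoxy)phenyl takes the place of 3-(trifluoromethyl)phenyl on a sulfonyl sulfur.

Within the data shown here, only one measured step bears on this change: a 1.2-fold lower number from compound 1 to compound 2 (0.08 log units; within the scatter). That step exchanged 4-(trifluoromethyl)phenyl for 3-(trifluoromethyl)phenyl and moved the number by no more than the scatter. Among the measured compounds shown here, no measured step shows what trifluoromethoxy does in place of trifluoromethyl, so the data give no ground for a shift in either direction.

In this assay the expected step is therefore none beyond the scatter, estimated as a 1.1-fold higher number from compound 2 to compound 3 (0.02 log units; within the scatter). For compound 3 the estimated value is 25000 nM, with an expected range from 12000 nM to 45000 nM.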

Compound 3, half-maximal inhibitory concentration: 51900 nM
Beside the measured number, compound 3's estimate is 2.1-fold (0.32 log units) below it; measured number above the stated range.
By their numbers in this assay, from the lowest: compounds 2, 1 and 3 (each within the scatter of the next, the first and the last beyond it).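

In this assay, within the data shown here, this is the first change on the sulfonyl sulfur to carry the number beyond the scatter, with a 2.2-fold higher number from compound 2 to compound 3 (0.34 log units; beyond the scatter) as a modest step, so the group on this sulfur is not wholly without influence on the read-out. Among these compounds, that step alters both the substituent and its place on the ring, however, and the single exchange of trifluoromethoxy in place of trifluoromethyl on an aromatic carbon, a 1.8-fold higher number from compound 1 to compound 3 (0.25 log units; within the scatter), stays within the scatter, so that exchange alone cannot be told apart from repeat variation here. Nothing in the information available speaks to why compound 3 gives the higher number of this pair.

Going by these compounds, what remains open is whether 3-(trifluoromethoxy)phenyl on the sulfonyl sulfur would stand with compound 2 or with compound 3, which would separate the part played by the group from the part played by its place on the ring. On these data alone, it is also open how far this position tolerates a different kind of group altogether, such as a nitrile, an amine or a carboxylic acid on the aromatic ring.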